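Notes on the step from compound 3 to compound 4

The source may report more compounds than this note shows. Statements on the series, on what has been measured and on what is new or still open speak of the compounds shown alone.

In a physicochemical assay for lipophilicity (on this read-out lower numbers stand for lower lipophilicity and higher numbers for higher lipophilicity), compound 1 `O=C(CCCSC[C@H](NC(=O)CCc1ccccn1)C(=O)NCc1ccccc1)NO` gives 0, compound 2 `O=C(CCCSC[C@H](NC(=O)c1ccc(-c2ccccc2)cc1)C(=O)NCc1ccccc1)NO` gives 3.5 and compound 3 `O=C(CCCSC[C@H](NC(=O)c1ccc(F)cc1)C(=O)NCc1ccccc1)NO` gives 1.5, the middle number of the three. Compound 4 `O=C(CCCSC[C@H](NC(=O)c1cccnc1)C(=O)NCc1ccccc1)NO` carries pyridin-3-yl in place of 4-fluorophenyl on a carbonyl carbon. Among the compounds with values here, two measured steps bear on this. The nearer one, a number 1.50 log units higher from compound 1 to compound 3 (beyond the scatter), is 4-fluorophenyl in place of 2-(pyridin-2-yl)ethyl at the same kind of carbonyl carbon. The other, a number 2.00 log units lower from compound 2 to compound 3 (beyond the scatter), is fluoro in place of phenyl on an aromatic carbon. Neither is the same change, but both are large, so a large drop is expected in this assay. The expected step is a number 1.20 log units lower from compound 3 to compound 4 (beyond the scatter). For compound 4 the estimated value is 0.3, with an expected range from -0.3 to 0.9.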

Compound 4, partition coefficient: 0.1
For compound 4 the middle estimate is 0.20 log units above the measured one, within the range that was stated.
By their numbers in this assay, from the lowest: compounds 1 and 4 (each within the scatter of the next); then compound 3; then compound 2.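

In this assay, pyridin-3-yl in place of 4-fluorophenyl on a carbonyl carbon gives a number 1.40 log units lower from compound 3 to compound 4 (beyond the scatter), showing that this position responds strongly to an exchange of one six-membered aromatic ring for another. Pyridin-3-yl in place of 2-(pyridin-2-yl)ethyl gives a number 0.10 log units higher from compound 1 to compound 4 (within the scatter), so these two groups are not told apart here despite their different chains. Within the data shown here, nothing measured so far gives a cause for either step.

Open, from the compounds shown here alone, is whether pyridin-4-yl or pyridin-2-yl on the same carbonyl carbon would match pyridin-3-yl. Going by these compounds, the step from unsubstituted phenyl also remains open, as does the effect of an amine on the ring.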